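A few compounds are considered here, and "the series" means these few. Any claim that something is new, unique, unknown or untested is made for them only; others in the source may bear on it.

Working notes on the series.

Compound 2 `CCCCC/C=C\C/C=C\C/C=C\C/C=C\CCCC(=O)OC[C@@H]1C=CC(=O)[C@@H](C2CCCC=C2C)O1` and compound 1 `CCCCC/C=C\C/C=C\C/C=C\C/C=C\CCCC(=O)OC[C@@H]1C=CC(=O)[C@@H](CC2=CCCCC2)O1` share one core. In a functional assay on LFCl2A cells (Rattus norvegicus) for cytotoxicity (a higher number here means a weaker inhibitor, a lower number a stronger inhibitor), compound 2 gives 5000 nM, and compound 1 gives 35000 nM. The change between them is (cyclohex-1-en-1-yl)methyl in place of 2-methylcyclohex-2-en-1-yl on a saturated ring carbon, and it produced a 7.0-fold higher number from compound 2 to compound 1 (0.85 log units; beyond the scatter).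

Compound 3 `CC/C=C\C/C=C\C/C=C\C/C=C\C/C=C\C/C=C\CCC(=O)OC[C@@H]1C=CC(=O)[C@@H](C2CCCC=C2C)O1` carries the same group as compound 2 on a different core; the difference between the two cores is not broken down here. In this assay compound 3 gives 65000 nM, the highest number of the three measured, though its gap to compound 1 stays within the scatter.

Compound 4 `CC/C=C\C/C=C\C/C=C\C/C=C\C/C=C\C/C=C\CCC(=O)OC[C@@H]1C=CC(=O)[C@@H](CC2=CCCCC2)O1` differs from compound 3 by (cyclohex-1-en-1-yl)methyl in place of 2-methylcyclohex-2-en-1-yl on a saturated ring carbon, the same change already seen from compound 2 to compound 1. Compound 4 is therefore expected to give a higher number than compound 3, around a 3.8-fold higher number from compound 3 to compound 4 (0.59 log units; beyond the scatter), resting on the earlier step of a 7.0-fold higher number from compound 2 to compound 1 (0.85 log units; beyond the scatter). The estimate for compound 4 in this assay is 250000 nM, expected between 80000 nM and 800000 nM.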

Compound 4, half-maximal inhibitory concentration: 30000 nM
For compound 4 the middle estimate is 8.3-fold (0.92 log units) above the measured one; the whole stated range lies above it.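

On the core of compound 3 the same change runs the other way, with a 2.2-fold lower number from compound 3 to compound 4 (0.34 log units; beyond the scatter) in this assay. The change therefore does not carry over from one core to the other in either direction or size: the same change on two cores in this assay, a 7.0-fold higher number (0.85 log units; beyond the scatter) from compound 2 to compound 1 and a 2.2-fold lower number (0.34 log units; beyond the scatter) from compound 3 to compound 4, 15-fold (1.18 log units) apart, beyond the scatter of two such steps. With one pair on each core, this shows that the step cannot be assumed to transfer within these four compounds, but it does not show what in the cores sets the difference or how the change would behave on a further core.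

Going by these compounds, it remains open whether the reversal would recur with a shorter chain on the ester. The same question stands for a benzyl group in place of (cyclohex-1-en-1-yl)methyl.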